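Pyrazolyl for Furanyl on the Aromatic Carbon

The source may hold more compounds than are shown below. What is called first, only, known or untested is meant among the compounds shown, and "the series" means these compounds.

Compound 1 `c1cncc(-c2ccccc2OCC2=NCCN2)c1`: 109%
Compound 2 `c1c[nH]c(-c2ccccc2OCC2=NCCN2)c1`: 99%
Compound 3 `c1ccc(-c2ccoc2)c(OCC2=NCCN2)c1`: 104%

In a functional assay with Alpha-1A adrenergic receptor (Homo sapiens) as the target, read by calcium flux (on this read-out higher numbers stand for larger maximal responses and lower numbers for smaller maximal responses), compound 3 stands between compound 1 and compound 2, with a number 5 percentage points lower from compound 1 to compound 3 (within the scatter) and a number 5 percentage points higher from compound 2 to compound 3 (within the scatter) both inside the scatter, so the three numbers cannot be told apart. Compound 4 `c1ccc(-c2cc[nH]n2)c(OCC2=NCCN2)c1` is not yet measured; it differs from compound 3 by 1H-pyrazol-3-yl in place of furan-3-yl on an aromatic carbon. Going by the values given here, the steps that bear on this exchange of one five-membered ring for another are a number 10 percentage points lower from compound 1 to compound 2 (within the scatter) and a number 5 percentage points higher from compound 2 to compound 3 (within the scatter), where a ring with a hydrogen-bond donor entered and then left without any change beyond the scatter. A step of similar size, that is none beyond the scatter, is therefore expected in this assay, a number 2 percentage points lower from compound 3 to compound 4 (within the scatter). Compound 4 is estimated at 102%, between 88% and 116%.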

Compound 4, largest response reached (reported as maximum), in percent of the reference or control that the assay uses: 119%
Estimate against measurement, compound 4: 17 percentage points below; measured number outside the range, above it.
By their numbers in this assay, from the lowest: compounds 2, 3, 1 and 4 (each within the scatter of the next, the first and the last beyond it).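

In this assay, going by these compounds alone, 1H-pyrazol-3-yl on this aromatic carbon gives the first steps at this position that lie beyond the scatter, a number 15 percentage points higher from compound 3 to compound 4 (beyond the scatter) and a number 20 percentage points higher from compound 2 to compound 4 (beyond the scatter), while the exchange for pyridin-3-yl stays inside it, a number 10 percentage points higher from compound 1 to compound 4 (within the scatter). Exchanges of one five-membered aromatic ring for another are thus not all silent here, and 1H-pyrazol-3-yl and 1H-pyrrol-2-yl, each counted with a hydrogen-bond donor, do not give the same response. No measurement at hand offers a reason for this. Open remains how an amine or a carboxylic acid on this aromatic carbon, or a methyl group on the pyrazole nitrogen, would change the maximal response.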